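Dropping the methyl from the benzyl substituent of compound 2

This account rests on a few compounds, and the source may have more. Where it says the series, first, only, none or still open, it means among the compounds named here.

Compound 2 `Cc1ccc(Cc2cnc(CCc3ccc(-c4ccccc4C(=O)O)cc3)[nH]2)cc1` and compound 1 `CCCCc1cnc(CCc2ccc(-c3ccccc3C(=O)O)cc2)[nH]1` share the core of compound 1. In an in vitro functional assay on cells for agonist activity at Bombesin receptor subtype-3 (Mus musculus), read by luminescence and calcium flux (a higher number here means that more compound is needed for the effect, a lower number that less compound is needed), compound 2 gives 162 nM, compound 1 gives 93 nM, and a 1.7-fold higher number from compound 1 to compound 2 (0.24 log units; within the scatter). Compound 3 `O=C(O)c1ccccc1-c1ccc(CCc2ncc(Cc3ccccc3)[nH]2)cc1` differs from compound 2 by hydrogen in place of methyl on an aromatic carbon. For the measured compounds named here, the single measured step, propyl to 4-methylphenyl, stayed within the scatter and bears only loosely on removing a methyl from that ring; nothing measured here separates 4-methylphenyl from phenyl. No step beyond the scatter is therefore expected: a 1.1-fold lower number from compound 2 to compound 3 (0.03 log units; within the scatter). Compound 3 is estimated at 150 nM, within 60 nM to 400 nM.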

Compound 3, half-maximal effective concentration: 11 nM
The estimate for compound 3 lay 14-fold (1.13 log units) above the measured number; measured number outside the range, below it.
By their numbers in this assay, from the lowest: compound 3; then compounds 1 and 2 (each within the scatter of the next).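

Hydrogen in place of methyl on the aromatic carbon para to a large group gives a 15-fold lower number from compound 2 to compound 3 (1.17 log units; beyond the scatter) in this assay, so this position responds strongly to a single methyl. Against propyl, the unsubstituted phenyl also gives a step beyond the scatter, an 8.5-fold lower number from compound 1 to compound 3 (0.93 log units; beyond the scatter), whereas 4-methylphenyl did not separate from propyl. No evidence available here accounts for the effect of this methyl.

As far as these compounds go, whether fluorine, chlorine or a methoxy group on that carbon would behave like hydrogen or like methyl stays open. So does the response to a longer chain in place of methyl.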